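The compounds below may be only part of what the source reports. "The series", "measured", "known", "first", "only" and "open" are said of these compounds alone.

Compound 3 `CC(C)(C)C(=O)SCCOP(=O)(OCCSC(=O)C(C)(C)C)OC[C@H]1O[C@@](C)(c2ccc3c(N)ncnn23)[C@H](O)[C@@H]1O` was tested in an in vivo ADME assay on the whole organism (Huh-7 cells, Homo sapiens) for pharmacokinetics, read by LC-MS, with a stated time of 24 h, tested at 10 uM, at a dose of 10 uM (a higher number here means more compound in the circulation at the dose given, a lower number less compound in the circulation), where its result stands as "not determined" (no result reported), so compound 3 has no place on the scale that the other two compounds define. Compound 1 `C=C[C@@]1(c2ccc3c(N)ncnn23)O[C@H](CO)[C@@H](O)[C@H]1O` gives 0.002 nM in this assay, and compound 2 `C#C[C@@]1(c2ccc3c(N)ncnn23)O[C@H](CO)[C@@H](O)[C@H]1O` gives 0.00066 nM. Compound 4 `C#C[C@@]1(c2ccc3c(N)ncnn23)O[C@H](COP(=O)(OCCSC(=O)C(C)(C)C)OCCSC(=O)C(C)(C)C)[C@@H](O)[C@H]1O` differs from compound 3 by ethynyl in place of methyl on a saturated ring carbon. For the measured compounds named here, the only measured step that touches an ethynyl group is a 3.0-fold lower number from compound 1 to compound 2 (0.48 log units; beyond the scatter), where ethynyl replaced vinyl rather than methyl, so it bears on the change only loosely. With no number for compound 3, the expectation for compound 4 is anchored on compound 2 and its value of 0.00066 nM, allowing for the modest drop seen in that step. Compound 4 is therefore expected to give about 0.001 nM, with a likely range from 0.0002 nM to 0.006 nM.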

Compound 4, maximal plasma concentration: 0.15 nM
Compound 4: the middle estimate sits 150-fold (2.18 log units) below what was measured, and the stated range ends below it.
By their numbers in this assay, from the lowest: compound 2; then compound 1; then compound 4.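

For the compounds shown here, compound 3 has no number in this assay, and no step to compound 4 can be read. The compounds shown leave open what ethynyl in place of methyl does to this read-out. No evidence on hand bears on the result.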